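Expected Antiproliferative Activity of Compound 3

The source may report more compounds than this note shows. Statements on the series, on what has been measured and on what is new or still open speak of the compounds shown alone.

compound 1: `COc1cc2c(Oc3ccc(NC(=O)Nc4ccccc4Cl)cc3)ccnc2cc1OCCCCCCC(=O)NO` — 1910 nM
compound 2: `COc1cc2c(Oc3ccc(NC(=O)N/N=C/c4ccc(F)cc4)cc3)ccnc2cc1OCCCCCCC(=O)NO` — 4920 nM

In a functional assay on A549 cells (Homo sapiens) for antiproliferative activity, read by MTT assay (a lower number here means a stronger inhibitor, a higher number a weaker inhibitor), compound 1 gives 1910 nM, the lowest of the two numbers, and compound 2 gives 4920 nM. Compound 3 `COc1cc2c(Oc3ccc(NC(=O)NNC(=O)c4ccccc4F)cc3)ccnc2cc1OCCCCCCC(=O)NO` has not been measured. It differs from compound 1 by ((2-fluorophenyl)carbonyl)amino in place of 2-chlorophenyl on an amide-type nitrogen. Going by the values given here, the only measured step that bears on this change is a 2.6-fold higher number from compound 1 to compound 2 (0.41 log units; beyond the scatter), which also exchanged the 2-chlorophenyl on that nitrogen for a different group. Compound 3 is therefore expected to show a modest step upward, a 1.8-fold higher number from compound 1 to compound 3 (0.26 log units; within the scatter). Compound 3 is estimated at 3500 nM, with a range from 1500 nM to 9000 nM.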

Compound 3, half-maximal inhibitory concentration: 2420 nM
Compound 3: middle estimate off by 1.4-fold (0.16 log units), on the high side, within the range that was stated.
By their numbers in this assay, from the lowest: compounds 1 and 3 (each within the scatter of the next); then compound 2.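

On the amide-type nitrogen, ((2-fluorophenyl)carbonyl)amino can stand in for 2-chlorophenyl with a 1.3-fold higher number from compound 1 to compound 3 (0.10 log units; within the scatter), so a group with more heavy atoms and a carbonyl keeps the level of compound 1 in this assay. Added size alone therefore does not set the number, as the two larger groups are separated by a 2.0-fold lower number from compound 2 to compound 3 (0.31 log units; beyond the scatter). No measurement available here explains these results.

The compounds shown leave open how much the carbonyl and the fluorine each contribute. They also leave open how a simple amine or a carboxylic acid would behave on this nitrogen.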